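The source may report more compounds than this note shows. Statements on the series, on what has been measured and on what is new or still open speak of the compounds shown alone.

Measured so far:
- compound 1, `CC(C)[C@]1(c2ccccc2)OC[C@H]([C@@H]2CCCCN2)O1`: 45 nM
- compound 2, `CC[C@]1(c2cccc(N=C=S)c2)OC[C@H]([C@@H]2CCCCN2)O1`: 590 nM
- compound 3, `NC[C@H]1COC(c2ccccc2)(c2ccccc2)O1`: 1400 nM

The read-out throughout is a functional assay (brain) for displacement of a labelled ligand, with Rattus norvegicus as the target; on this read-out higher numbers stand for weaker inhibition and lower numbers for stronger inhibition. On these three numbers compound 3 gives the highest, that is the weakest inhibition of the set. Compound 2 gives a lower number than compound 3, and that gap lies beyond the scatter. Compound 1 gives a lower number still, and the gap from compound 3 to compound 1 is well beyond the scatter. Among the measured compounds shown here, no pair of measured compounds differs in only one place, so no single-step comparison is available from the measured set; compounds 1 and 2 share a piperidin-2-yl group where compound 3 carries aminomethyl, and both give stronger inhibition than compound 3, but other parts of the structures differ as well.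

The next compound, compound 4, `CN[C@@H](C)[C@H]1COC(c2ccccc2)(c2ccccc2)O1`, has not been measured in this assay. It differs from compound 3 as follows:

1-(methylamino)ethyl in place of aminomethyl on a saturated ring carbon

The change retains one hydrogen-bond donor and one acceptor and adds two carbons. On the numbers shown, a step of modest size toward stronger inhibition is expected from compound 3 to compound 4, a 2.8-fold lower number from compound 3 to compound 4 (0.45 log units; beyond the scatter), though it may also fall within the scatter. For compound 4 the estimate in this assay is 500 nM, with a range from 150 nM to 1800 nM.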

Compound 4, inhibition constant: 703 nM
For compound 4 the middle estimate is 1.4-fold (0.15 log units) below the measured one; the measured number falls inside the stated range.
By their numbers in this assay, from the lowest: compound 1; then compounds 2, 4 and 3 (each within the scatter of the next, the first and the last beyond it).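

In this assay, among the compounds shown here, 1-(methylamino)ethyl in place of aminomethyl on the saturated ring carbon gives a 2.0-fold lower number from compound 3 to compound 4 (0.30 log units; within the scatter) and thus provides the first single-place comparison, one on which the two groups cannot be told apart. At this position, next to the ring oxygen, a group of 4 heavy atoms with a defined stereocentre stands in place of one of 2 heavy atoms without a step beyond the scatter, and the hydrogen-bond donor and acceptor counts stay the same. Nothing in the available data explains this result.

A 1-aminoethyl or a (methylamino)methyl group at this position would separate the methyl on the nitrogen from the methyl on the chain carbon, and the opposite configuration at the new stereocentre would show whether that centre matters. Also open, going by these compounds, is whether piperidin-2-yl, which compound 1 and compound 2 carry on cores that differ in other places, would give a step beyond the scatter on the core of compound 3.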